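A Double Bond Enters the Saturated Side Ring

The compounds below may be only part of what the source reports. "The series", "measured", "known", "first", "only" and "open" are said of these compounds alone.

Two compounds share a core and were tested in an assay on HEK293 cells for inhibition of Voltage-dependent N-type calcium channel subunit alpha-1B (Homo sapiens), read by fluorescence and calcium flux, with a stated time of 5 min; a lower number here means a stronger inhibitor, a higher number a weaker inhibitor. Compound 1 `COc1ccccc1-n1nc(C2CC(C)(C)OC(C)(C)C2)cc1-c1ccc(Cl)cc1` carries a 2,2,6,6-tetramethyloxan-4-yl group on the core, and in this assay compound 1 gives 1 nM. Compound 2 `COc1ccccc1-n1nc([C@@H]2CCO[C@H](C(C)C)C2)cc1-c1ccc(Cl)cc1` carries a 2-isopropyloxan-4-yl group in the same place, and in this assay compound 2 gives 7 nM. Among the compounds with values here, the single measured step, a 7.0-fold higher number from compound 1 to compound 2 (0.85 log units; beyond the scatter), shows that swapping the tetramethyl ring for the isopropyl ring weakened inhibition. Compound 2 therefore stands as the weaker of the two measured compounds.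

Compound 3 `COc1ccccc1-n1nc(C2=CC(C)(C)OC(C)(C)C2)cc1-c1ccc(Cl)cc1` returns to the tetramethyl pattern but with one change: a group of 10 heavy atoms (9 carbon, 1 oxygen; one six-membered non-aromatic ring with 1 hetero atom) in place of a group of 9 heavy atoms (8 carbon, 1 oxygen; one six-membered non-aromatic ring with 1 hetero atom), on an aromatic carbon. Within the data shown here, the new ring is the tetramethyl ring of compound 1 with a double bond added, so the one measured step bears on it in reverse. Because compound 1 gives 1 nM with the fully saturated tetramethyl ring, compound 3 is expected to land near that number. The expected step is a 3.5-fold lower number from compound 2 to compound 3 (0.54 log units; beyond the scatter), toward a lower number. Compound 3 is thus estimated at 2 nM, within a range from 0.7 nM to 6 nM.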

Compound 3, half-maximal inhibitory concentration: 3 nM
Compound 3: middle estimate off by 1.5-fold (0.18 log units), on the low side; the measured number falls inside the stated range.
By their numbers in this assay, from the lowest: compound 1; then compound 3; then compound 2.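

In this assay, putting a double bond into the tetramethyl ring gives a 3.0-fold higher number from compound 1 to compound 3 (0.48 log units; beyond the scatter), so this position on the shared core responds to a change within the ring itself, even with all four methyl groups still present. Set against the 2-isopropyloxan-4-yl ring, the unsaturated tetramethyl ring gives a 2.3-fold lower number from compound 2 to compound 3 (0.37 log units; beyond the scatter), which places it between the two saturated rings in this assay and shows that the double bond does not cost as much as the move to the isopropyl ring. The compounds come with no supporting measurement that could explain either step, so the reason for these shifts remains unknown.

As far as these compounds go, all three compounds keep the oxygen in the side ring, so its part in the result stays open, and an amine nitrogen in its place would test that directly. It is also unclear whether a double bond would have a similar effect in the 2-isopropyloxan-4-yl ring, or whether a hydroxyl group on the tetramethyl ring would be tolerated at this position.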